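Benzofuran replaced by a small amide on the shared core

The compounds below may be only part of what the source reports. "The series", "measured", "known", "first", "only" and "open" are said of these compounds alone.

Compound 2 `c1ccc(-c2ccc(Cn3cncc3CNc3ccc(-c4cc5ccccc5o4)c(-c4ccccc4)c3)cc2)cc1` reaches in a toxicity assay on NIH3T3 cells (Mus musculus) for cytotoxicity, read by resazurin assay (on this read-out higher numbers stand for an effect only at larger amounts of compound and lower numbers for an effect already at smaller amounts), only a limit, > 10000 nM; of the two values shown it sits at the limit of > 10000 nM in this assay, at which 1 of the 2 values shown sits. Compound 1 `O=C(c1ccc(NCc2cncn2Cc2ccc(-c3ccccc3)cc2)cc1-c1ccccc1)N1CCCCC1` also gives only a limit in this assay, > 1000 nM. The step that the two limits leave unreadable from compound 1 to compound 2 is therefore unreadable in size and direction. Compound 3 `CN(C)C(=O)c1ccc(NCc2cncn2Cc2ccc(-c3ccccc3)cc2)cc1-c1ccccc1` differs from compound 2 by dimethylcarbamoyl in place of 1-benzofuran-2-yl on an aromatic carbon. No readable step bears on this change, so no shift beyond a further limit is expected. Compound 3 is estimated at 20000 nM, between 3000 nM and 100000 nM. The expected step that the limit leaves unreadable from compound 2 to compound 3 is thus no readable change.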

Compound 3, half-maximal effective concentration: > 1000 nM
Compound 3: a limit, no number; the forecaster's own chance of this, stated with the estimate: 80%; the middle value is on the limit's open side.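

In this assay compound 3 gives only a limit, > 1000 nM. Compound 1 and compound 2 also give only limits, so no step among these three compounds can be read. The compounds shown leave open at what concentration any of them would reach a half-maximal effect.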